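The source may hold more compounds than are shown below. What is called first, only, known or untested is meant among the compounds shown, and "the series" means these compounds.

Three compounds have been measured in a functional assay on SGC-7901 cells (Homo sapiens) for antiproliferative activity, read by MTT assay, with a stated time of 72 h (a higher number here means a weaker inhibitor, a lower number a stronger inhibitor), and read as follows

Compound 1 `COc1cc(-n2cnc3ccc(-c4cc(F)ccc4F)cc32)cc(OC)c1OC` gives 6590 nM
Compound 2 `COc1cc(-n2cnc3ccc(-c4ccc(C(F)(F)F)cc4)cc32)cc(OC)c1OC` gives 890 nM
Compound 3 `COc1cc(-n2cnc3ccc(-c4cccc(F)c4)cc32)cc(OC)c1OC` gives 2490 nM

Compound 3 holds the middle place of these three numbers, lying under compound 1 and over compound 2. Compound 4 `COc1ccc(-c2ccc3ncn(-c4cc(OC)c(OC)c(OC)c4)c3c2)cc1` has not yet been measured. It differs from compound 3 by 4-methoxyphenyl in place of 3-fluorophenyl on an aromatic carbon on an aromatic carbon of the shared core, with 4-methoxyphenyl in place of 3-fluorophenyl.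

Among the compounds with values here, three measured steps bear on this exchange. The nearest are a 2.8-fold higher number from compound 2 to compound 3 (0.45 log units; beyond the scatter) and a 2.6-fold lower number from compound 1 to compound 3 (0.42 log units; beyond the scatter), while a 7.4-fold lower number from compound 1 to compound 2 (0.87 log units; beyond the scatter) spans the whole set. All three are modest, so no large step is expected in this assay. Within the data shown here, no compound with a methoxy group has been measured. Compound 2 is the closest comparison by name, and the step of a 2.8-fold higher number from compound 2 to compound 3 (0.45 log units; beyond the scatter) suggests a small move toward a lower number. The expected change is a 1.7-fold lower number from compound 3 to compound 4 (0.22 log units; within the scatter). For compound 4 the estimated value is 1500 nM, with an expected range of 550 nM to 4000 nM.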

Compound 4, half-maximal inhibitory concentration: 82 nM
The estimate for compound 4 lay 18-fold (1.26 log units) above the measured number, outside the stated range (below it).
By their numbers in this assay, from the lowest: compound 4; then compound 2; then compound 3; then compound 1.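

In this assay, within the data shown here, this aromatic carbon of the shared core proves far more responsive than the earlier compounds indicated: 4-methoxyphenyl in place of 3-fluorophenyl gives a 30-fold lower number from compound 3 to compound 4 (1.48 log units; beyond the scatter), a large step where all earlier steps were modest. The change also stays large against the other two aryl groups, with an 11-fold lower number from compound 2 to compound 4 (1.04 log units; beyond the scatter) for methoxy in place of trifluoromethyl and an 80-fold lower number from compound 1 to compound 4 (1.91 log units; beyond the scatter) for 4-methoxyphenyl in place of 2,5-difluorophenyl. Compound 4 is therefore the strongest inhibitor of the four, and a single methoxy-bearing aryl group outperforms all the fluorinated ones shown.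

The compounds shown leave open whether a hydroxyl group, an amine or a longer alkoxy chain in place of the methoxy would hold this level of activity. No evidence is available that accounts for the size of this step.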